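Swapping the Pyrazole Ring on a Diaryl Urea Series

A few compounds are considered here, and "the series" means these few. Any claim that something is new, unique, unknown or untested is made for them only; others in the source may bear on it.

Compound 1 `Cc1cc(C)c(NC(=O)N(Cc2ccc(-c3cccnc3)cc2)C2CCCCCC2)c(C)c1` gives 0.58 mg/kg in a functional assay on a cell-free system (plasma) with sterol O-acyltransferase, Soat (Rattus norvegicus) as the target; on this read-out lower numbers stand for an effect already at smaller amounts and higher numbers for an effect only at larger amounts of compound.
Compound 2 `Cc1cc(C)c(NC(=O)N(Cc2ccc(-c3cn[nH]c3)cc2)C2CCCCCC2)c(C)c1` reaches only the limit > 1 mg/kg in this assay, so no number is known for it.

Within the data shown here, only one step joins the two measured compounds: an at least 1.7-fold higher number from compound 1 to compound 2 (0.23 log units; that floor lies within the scatter). That step carries a floor, and the floor lies within the usual scatter, so it is not known whether the replacement truly changed anything (the limit of > 1 mg/kg in this assay, at which 1 of the 2 values shown sits). Compound 2 therefore stands at the limit of this assay, with its number open upward.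

Compound 3 `Cc1cc(C)c(NC(=O)N(Cc2ccc(-c3ccn(C)n3)cc2)C2CCCCCC2)c(C)c1` differs from compound 2 in the same place, where (1-methyl-1H-pyrazol-3-yl in place of 1H-pyrazol-4-yl on an aromatic carbon). Among the measured compounds shown here, no measured step covers this particular exchange; the step from compound 1 to compound 2 touches the same ring position but swaps a different pair of groups, so it gives only a rough guide. With nothing pointing strongly either way, compound 3 is expected to sit close to compound 2, which means a step that the limit leaves unreadable from compound 2 to compound 3 in this assay. The estimate for compound 3 is 1.5 mg/kg, with a range from 0.5 mg/kg to 5 mg/kg, and a fair chance that only a limit is reported again.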

Compound 3, dose for half-maximal effect: < 1 mg/kg
Compound 3: a limit, no number (the forecaster's own chance of this, stated with the estimate: 55%); middle value at least 1.5-fold (0.17 log units) from the limit.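

In this assay compound 3 gives < 1 mg/kg, which is a limit of the assay and not a number. Among these compounds, on the aromatic carbon para to a large group, putting 1-methyl-1H-pyrazol-3-yl in place of 1H-pyrazol-4-yl gives a number no higher from compound 2 to compound 3 (the limit leaves the size open), so for the first time a five-membered ring here does not sit at the upper limit, although the ring that enters has no hydrogen-bond donor while the one that leaves has one. The comparison with compound 1 cannot be read, and neither step has a known size, because compound 3 carries a limit: the limit of < 1 mg/kg in this assay, at which 1 of the 3 values shown sits.

This exchange adds a methyl group and also shifts the point where the ring attaches, so the compounds shown cannot tell which of the two matters. 1-Methyl-1H-pyrazol-4-yl or 1H-pyrazol-3-yl at this position would separate the two, and a true number for compound 3 would be needed before its place relative to compound 1 could be judged.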